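Moving Two Fluorines Around the Cyclopropyl Phenyl Ring

A few compounds are considered here, and "the series" means these few. Any claim that something is new, unique, unknown or untested is made for them only; others in the source may bear on it.

The series shares one core, seen in compound 1 `CC[C@H](C)[C@H](N)CN(C(=O)[C@@H]1C[C@H]1c1ccccc1)c1ccc(-c2ccccc2)cc1`, which in a functional assay for agonist activity at G protein-coupled receptor 88 (Homo sapiens), read by HTRF and cAMP accumulation (on this read-out higher numbers stand for an effect only at larger amounts of compound and lower numbers for an effect already at smaller amounts), gives 230 nM; 800 nM (2 entries), as noted in the several entries of compound 1 in this assay, 230 nM; 800 nM (2 entries). Compound 2 `CC[C@H](C)[C@H](N)CN(C(=O)[C@@H]1C[C@H]1c1ccccc1Cl)c1ccc(-c2ccccc2)cc1`, with a 2-chlorophenyl on the cyclopropane, reaches only the limit of > 25000 nM in this assay, a limit rather than a number (the limit of > 25000 nM in this assay, at which 1 of the 3 values shown sits). Among the measured compounds shown here, compound 3 `CC[C@H](C)[C@H](N)CN(C(=O)[C@@H]1C[C@H]1c1cc(F)ccc1F)c1ccc(-c2ccccc2)cc1` gives 770 nM in this assay; it holds the only single number in this set. For the measured compounds named here, the step of an at least 32-fold lower number from compound 2 to compound 3 (1.51 log units; beyond the scatter) is the one measured change on this phenyl ring.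

Compound 4 `CC[C@H](C)[C@H](N)CN(C(=O)[C@@H]1C[C@H]1c1ccc(F)c(F)c1)c1ccc(-c2ccccc2)cc1` differs from compound 3 by 3,4-difluorophenyl in place of 2,5-difluorophenyl on a saturated ring carbon. Going by the values given here, no measured step moves fluorines from one position to another on this ring; the step from compound 2 to compound 3 exchanged chlorine for two fluorines and cannot be carried over directly. The account therefore expects compound 4 to show a step of a 1.3-fold higher number from compound 3 to compound 4 (0.11 log units; within the scatter) in this assay, a change that may stay within the scatter. Compound 4 is estimated at 1000 nM, in the range 300 nM to 4000 nM.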

Compound 4, half-maximal effective concentration: 720 nM
Estimate against measurement, compound 4: 1.4-fold (0.14 log units) above; measured number inside the range.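

Moving the fluorines, the first measured change on this phenyl ring that keeps the same atoms, from 2,5-difluorophenyl to 3,4-difluorophenyl on the saturated ring carbon leaves the read-out in this assay within the scatter (a 1.1-fold lower number from compound 3 to compound 4 (0.03 log units; within the scatter)), so these two fluorine arrangements cannot be told apart here. Compound 4 also shows a large step away from the 2-chlorophenyl compound (an at least 34-fold lower number from compound 2 to compound 4 (1.54 log units; beyond the scatter)), which gives a second difluorophenyl compound on the same side of that gap as compound 3. That step starts from compound 2, whose entry is a limit and not a number: the limit of > 25000 nM in this assay, at which 1 of the 4 values shown sits.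

The compounds shown leave open how a single fluorine, a methoxy group or a nitrile on this phenyl ring would read. They also leave open whether a chlorine placed elsewhere on the ring would give the same gap.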